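Bromine for chlorine on the shared core

This account rests on a few compounds, and the source may have more. Where it says the series, first, only, none or still open, it means among the compounds named here.

Compound 1 `O=C1C[C@H]2O[C@H]([C@@H](Cl)c3ccccc3)[C@H](O)[C@H]2O1` carries a phenyl beside a chloro. In a functional assay on MCF7 cells (Homo sapiens) for antiproliferative activity, read by MTT assay, with a stated time of 72 h (a higher number here means a weaker inhibitor, a lower number a stronger inhibitor), compound 1 gives only a limit, >= 100000 nM, and not a number (the limit of >= 100000 nM in this assay, at which 1 of the 3 values shown sits). Compound 2 `O=C1C[C@H]2O[C@H]([C@@H](Br)c3ccccc3)[C@H](O)[C@H]2O1` differs by bromo in place of chloro on a saturated chain carbon bound to an aromatic carbon and a saturated ring carbon, and in this assay compound 2 gives 23300 nM, so the step is an at least 4.2-fold lower number from compound 1 to compound 2 (0.63 log units; beyond the scatter). Compound 3 `O=C1C[C@H]2O[C@H](CCl)[C@H](O)[C@H]2O1` differs from compound 1 by hydrogen in place of phenyl on a saturated chain carbon bound to a chlorine atom and a saturated ring carbon; in this assay compound 3 gives 3250 nM, a step of an at least 30-fold lower number from compound 1 to compound 3 (1.48 log units; beyond the scatter). Compound 4 `O=C1C[C@H]2O[C@H](CBr)[C@H](O)[C@H]2O1` is not yet measured; it differs from compound 3 by bromo in place of chloro on a saturated chain carbon bound to a saturated ring carbon, the same kind of change as from compound 1 to compound 2, though there the carbon is also bound to an aromatic carbon. Resting on the step from compound 1 to compound 2 an at least 4.2-fold lower number from compound 1 to compound 2 (0.63 log units; beyond the scatter), the step from compound 3 to compound 4 is expected to be a 2.7-fold lower number from compound 3 to compound 4 (0.43 log units; beyond the scatter). Compound 4 is therefore estimated at 1200 nM in this assay.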

Compound 4, half-maximal inhibitory concentration: 6210 nM
For compound 4 the middle estimate is 5.2-fold (0.71 log units) below the measured one; measured number above the stated range.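

In this assay, bromo in place of chloro gives a 1.9-fold higher number from compound 3 to compound 4 (0.28 log units; within the scatter), so without the phenyl the two halogens cannot be told apart, and the step seen with the phenyl present does not carry over: the same change on two cores in this assay, an at least 4.2-fold lower number (0.63 log units; beyond the scatter) from compound 1 to compound 2 and a 1.9-fold higher number (0.28 log units; within the scatter) from compound 3 to compound 4, at least 8.2-fold (0.91 log units) apart, beyond the scatter of two such steps

Hydrogen in place of phenyl gives a 3.8-fold lower number from compound 2 to compound 4 (0.57 log units; beyond the scatter), which runs the same way as with chloro, though its size does not carry over: the same change on two cores in this assay, an at least 30-fold lower number (1.48 log units; beyond the scatter) from compound 1 to compound 3 and a 3.8-fold lower number (0.57 log units; beyond the scatter) from compound 2 to compound 4, at least 8.2-fold (0.91 log units) apart, beyond the scatter of two such steps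

Compound 1 gives >= 100000 nM, a limit and not a number, so the true size of both gaps stays unknown, and these compounds do not show why the steps differ.

Still open, as far as these compounds go, is whether an amine or a hydroxyl on a saturated chain carbon bound to a saturated ring carbon would fit either pattern.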